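The source may report more compounds than this note shows. Statements on the series, on what has been measured and on what is new or still open speak of the compounds shown alone.

Compound 1 `Cc1ccccc1NC(=S)N1CCc2c(sc(NC(=O)c3ccccc3Cl)c2C(N)=O)C1` gives 22600 nM in a functional assay on HL-60 cells (Homo sapiens) for antiproliferative activity, with a stated time of 24 h; a higher number here means a weaker inhibitor, a lower number a stronger inhibitor. That is the higher of the two numbers recorded in this assay; the nearest point is compound 2 `COc1ccc(NC(=S)N2CCc3c(sc(NC(=O)c4ccccc4Cl)c3C(N)=O)C2)cc1`, which gives 15700 nM in this assay, and the step of a 1.4-fold lower number from compound 1 to compound 2 (0.16 log units; within the scatter) lies within the scatter, so the two compounds cannot be told apart on these numbers. That step changes only the group on the amide-type nitrogen, 4-methoxyphenyl in place of 2-methylphenyl.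

Compound 3 `Cc1ccccc1NC(=S)N1CCc2c(sc(NC(=O)c3ccccc3C(F)(F)F)c2C(N)=O)C1` differs from compound 1 at the other end of the molecule: trifluoromethyl in place of chloro on an aromatic carbon. Among the measured compounds shown here, no measured step touches this part of the shared core; the one recorded step, from compound 1 to compound 2, concerns the other aryl group and was within the scatter, so it carries no information on the side bearing the 2-chlorophenyl group. With nothing further to draw on, no step beyond the scatter is assumed in either direction, and the estimated step is a 1.0-fold lower number from compound 1 to compound 3 (0.01 log units; within the scatter). Compound 3 is therefore expected at 22000 nM in this assay, with a range from 7000 nM to 70000 nM.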

Compound 3, half-maximal inhibitory concentration: 25100 nM
Estimate against measurement, compound 3: 1.1-fold (0.06 log units) below; measured number inside the range.
By their numbers in this assay, from the lowest: compounds 2, 1 and 3 (each within the scatter of the next).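

In this assay, among the compounds shown here, the replacement of chloro by trifluoromethyl on an aromatic carbon, ortho to a large group, gives a 1.1-fold higher number from compound 1 to compound 3 (0.05 log units; within the scatter) and so provides the first reading on the 2-chlorophenyl side of the shared core. Going from one heavy atom to four at this position, with no hydrogen-bond donor or acceptor on either group, produces no step that can be told apart from the scatter, so on these numbers 2-chlorophenyl and 2-(trifluoromethyl)phenyl are interchangeable in this series. No information on why this change leaves the number within the scatter is available, and this reading is confined to one pair of compounds.

Going by these compounds, whether this position stays equally flat for groups of another kind remains open, for example a primary amine, a carboxylic acid or a methoxy group on the same carbon, or plain hydrogen in place of chloro. Also open is whether any change at this position or on the other aryl group can bring the number clearly beyond the scatter, since every comparison shown so far stays within it.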